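Methylation of a Phenol in a Flavone Series

The compounds below may be only part of what the source reports. "The series", "measured", "known", "first", "only" and "open" are said of these compounds alone.

Compound 3 `O=c1cc(-c2ccccc2)oc2cc(O)c(OCCCCN3CCCCC3)c(O)c12` is the weakest point of the three measured compounds: in a functional assay on HepG2 cells (Homo sapiens) for antiproliferative activity, read by MTT assay, with a stated time of 48 h (a higher number here means a weaker inhibitor, a lower number a stronger inhibitor), compound 3 gives > 100000 nM, a limit of the assay rather than a number. That limit is the one recorded at the limit of > 100000 nM in this assay, at which 1 of the 3 values shown sits. Compound 1 `COc1cc2oc(-c3ccccc3)cc(=O)c2c(O)c1OCCCCN1CCCC1` gives 4900 nM in this assay, and compound 2 `COc1cc2oc(-c3ccccc3)cc(=O)c2c(O)c1OCCCN1CCCC1` gives 4300 nM. Among the compounds with values here, the only step measured between two compounds that differ in one place is a 1.1-fold lower number from compound 1 to compound 2 (0.06 log units; within the scatter), which concerns the amine-bearing chain and not the oxygen substituents.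

Compound 4 `COc1cc2oc(-c3ccccc3)cc(=O)c2c(O)c1OCCCCN1CCCCC1` is to be measured. It differs from compound 3 by methyl in place of hydrogen on an oxygen on an aromatic ring. Within the data shown here, no measured step addresses this hydroxy-to-methoxy change directly; the step from compound 1 to compound 2 is silent on it. What the numbers do show is that compound 1, which carries a methoxy on its core, gives 4900 nM. Compound 3, with its free hydroxy, reaches only a limit of the assay.

Compound 4 is therefore expected to leave the limit and land near compound 1, at an estimated 6000 nM in this assay, with a likely range from 2000 nM to 25000 nM. This estimate means a step of an at least 16-fold lower number from compound 3 to compound 4 (1.22 log units; beyond the scatter), a considerable gain in potency, though its exact size cannot be fixed from a limit.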

Compound 4, half-maximal inhibitory concentration: 21000 nM
Estimate against measurement, compound 4: 3.5-fold (0.54 log units) below; the measured number falls inside the stated range.
By their numbers in this assay, from the lowest: compounds 2 and 1 (each within the scatter of the next); then compound 4. At a limit, above all of these: compound 3.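

In this assay the change from hydroxy to methoxy now has a step of its own, an at least 4.7-fold lower number from compound 3 to compound 4 (0.67 log units; beyond the scatter), which lies beyond the scatter with the piperidin-1-yl chain end held the same. Compound 3 stands at a limit of the assay, so this step gives a bound and does not fix the true size of the change: the limit of > 100000 nM in this assay, at which 1 of the 4 values shown sits. The new compound also shows that the amine at the chain end can shift the number beyond the scatter, where the earlier step on the chain did not: piperidin-1-yl in place of pyrrolidin-1-yl gives a 4.3-fold higher number from compound 1 to compound 4 (0.63 log units; beyond the scatter), and (piperidin-1-yl)methyl in place of pyrrolidin-1-yl gives a 4.9-fold higher number from compound 2 to compound 4 (0.69 log units; beyond the scatter).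

The compounds shown leave open whether the hydroxy to methoxy change reads the same way with pyrrolidin-1-yl at the chain end, since only the piperidin-1-yl pair addresses it. Also open, on these data alone, is how an ethoxy in place of the methoxy, or a morpholin-4-yl at the chain end, would read in this assay.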